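Swapping the aryl group on the ring nitrogen

The source may report more compounds than this note shows. Statements on the series, on what has been measured and on what is new or still open speak of the compounds shown alone.

Compound 1 `N#CC1=C(N)Oc2c(c3nc4ccccc4nc3c3ccccc23)C12C(=O)N(Cc1cnnn1-c1cccc(Br)c1)c1ccccc12`, compound 2 `CC(=O)Nc1ccc(-n2nncc2CN2C(=O)C3(C(C#N)=C(N)Oc4c3c3nc5ccccc5nc3c3ccccc43)c3ccccc32)cc1` and compound 3 `N#CC1=C(N)Oc2c(N)cc3nc4ccccc4nc3c2C12C(=O)N(Cc1cnnn1-c1ccccc1Br)c1ccccc12` share one core and differ mainly in the aromatic ring carried on an aromatic nitrogen. In a functional assay on HCT-116 cells (Homo sapiens) for antiproliferative activity, read by MTT assay, with a stated time of 48 h (a higher number here means a weaker inhibitor, a lower number a stronger inhibitor), compound 1 gives only a limit of the assay, > 50000 nM, and no number. Compound 2 likewise gives only a limit, > 50000 nM. Within the data shown here, compound 3 is the one compound of the three with an actual number, 12400 nM, so among the values shown it alone stands at a readable point. Among the measured compounds shown here, the single measured step, a step that the two limits leave unreadable from compound 1 to compound 2, has no readable size because both of its values sit at the limit of > 50000 nM in this assay, at which 2 of the 3 values shown sit.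

Compound 4 `COc1cc(-n2nncc2CN2C(=O)C3(C(C#N)=C(N)Oc4c(N)cc5nc6ccccc6nc5c43)c3ccccc32)c(OC)cc1Cl` is not yet measured. It differs from compound 3 in one place: 4-chloro-2,5-dimethoxyphenyl in place of 2-bromophenyl on an aromatic nitrogen. For the measured compounds named here, the only measured step at this position gives neither a size nor a direction, so no step in this assay can be expected with any confidence beyond the scatter, and a result at a limit remains possible. The estimate for compound 4 is 15000 nM, in a range from 4000 nM to 50000 nM. The expected step, a 1.2-fold higher number from compound 3 to compound 4 (0.08 log units; within the scatter), is set near zero for want of any readable guide.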

Compound 4, half-maximal inhibitory concentration: > 50000 nM
Compound 4 ended at the assay's limit; the forecaster's own chance of this, stated with the estimate: 35%; middle value at least 3.3-fold (0.52 log units) from the limit.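

Among these compounds, this change gives the first step at this position that can be read, as the one earlier step, between two limits, cannot be: in this assay, the swap gives an at least 4.0-fold higher number from compound 3 to compound 4 (0.60 log units; beyond the scatter). The aromatic ring on this nitrogen therefore affects the read-out on the core of compound 3, and 4-chloro-2,5-dimethoxyphenyl does not serve as an equal replacement for 2-bromophenyl. The step gives only the smallest possible change and not its true size, because compound 4 ended at a limit of the assay, which leaves no measured number to compare with that of compound 3: the limit of > 50000 nM in this assay, at which 3 of the 4 values shown sit.

The swap removes the bromine and brings in the chlorine and both methoxy groups together, so the compounds shown cannot say which of these changes accounts for the weaker result, or whether it takes all of them. As far as these compounds go, it also remains open whether a plain phenyl with no added group, or a phenyl carrying an amine or a carboxylic acid, would give a readable number at this position or a stronger one than compound 3.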